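Bromo for hydrogen on a fused aromatic ring, two cores

The source may hold more compounds than are shown below. What is called first, only, known or untested is meant among the compounds shown, and "the series" means these compounds.

Measured so far in a functional assay on cells (Cancer cell lines, Homo sapiens) for cytotoxicity, read by sulforhodamine B assay, with a stated time of 48 h; a higher number here means a weaker inhibitor of growth, a lower number a stronger inhibitor of growth:
compound 1 `O=C1N=C(N2N=C(c3ccccc3)CC2c2ccccc2O)S/C1=C1/C(=O)Nc2ccccc21` gives 17800 nM
compound 2 `O=C1N=C(N2N=C(c3ccccc3)CC2c2ccccc2O)S/C1=C1/C(=O)Nc2ccc(Br)cc21` gives 630 nM
compound 3 `COc1ccc(C2=NN(C3=NC(=O)/C(=C4\C(=O)Nc5ccccc54)S3)C(c3ccc(Cl)cc3)C2)cc1` gives 100000 nM

Compound 2 differs from compound 1 by bromo in place of hydrogen on an aromatic carbon, and this change made a 28-fold lower number from compound 1 to compound 2 (1.45 log units; beyond the scatter). Compound 3 has the highest number of the three; the difference between its core and the core of compound 1 is not broken down here.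

Compound 4 `COc1ccc(C2=NN(C3=NC(=O)/C(=C4\C(=O)Nc5ccc(Br)cc54)S3)C(c3ccc(Cl)cc3)C2)cc1` is not yet measured. It differs from compound 3 by bromo in place of hydrogen on an aromatic carbon, the same change as from compound 1 to compound 2, at the same place on the ring. In this assay, within the data shown here, compound 4 is expected to give a step of a 20-fold lower number from compound 3 to compound 4 (1.30 log units; beyond the scatter), resting on the single earlier step of a 28-fold lower number from compound 1 to compound 2 (1.45 log units; beyond the scatter) and on the high starting number of compound 3. The estimate for compound 4 in this assay is 5000 nM, with a range from 1200 nM to 40000 nM.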

Compound 4, concentration for total growth inhibition: 370 nM
Estimate against measurement, compound 4: 14-fold (1.13 log units) above, and the stated range ends above it.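

In this assay, bromo in place of hydrogen on an aromatic carbon gives a 270-fold lower number from compound 3 to compound 4 (2.43 log units; beyond the scatter), so the direction of the change seen on the core of compound 1 carries over to the core of compound 3, while its size does not: the same change on two cores in this assay, a 28-fold lower number (1.45 log units; beyond the scatter) from compound 1 to compound 2 and a 270-fold lower number (2.43 log units; beyond the scatter) from compound 3 to compound 4, 9.6-fold (0.98 log units) apart, beyond the scatter of two such steps

For planning within this series, the step measured on one core therefore gives the direction on the other, but it does not serve as a reliable measure of the size. Compound 1 and compound 3 differ in more than one place, and these two pairs do not show which of those differences goes with the larger step, nor whether the same holds on any further core.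

From the compounds shown here alone, it remains open whether fluoro or an amine in place of the same hydrogen would give a step like that of bromo on either core. Also open, going by these compounds, is whether bromo at another aromatic carbon of the same ring would lower the number to a similar extent.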